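Stereoisomers of a Hydroxylated Piperidine Carboxylic Acid

The source may report more compounds than this note shows. Statements on the series, on what has been measured and on what is new or still open speak of the compounds shown alone.

Measured compounds:
compound 1 `O=C(O)[C@H]1NC[C@@H](O)[C@H](O)[C@H]1O` — 4.2%
compound 2 `O=C(O)[C@H]1NC[C@H](O)[C@H](O)[C@H]1O` — 21%
compound 3 `O=C(O)[C@@H]1NC[C@@H](O)[C@@H](O)[C@@H]1O` — 7.2%

In an assay for inhibition of alpha-N-acetylgalactosaminidase (Gallus gallus), tested at 1000 uM (a higher number here means more inhibition at the concentration tested (going by the name of the read-out), a lower number less inhibition), compound 3 stands second highest of the three numbers, with compound 1 nearest at a number 3 percentage points higher from compound 1 to compound 3 (within the scatter) and compound 2 furthest at a number 13.8 percentage points lower from compound 2 to compound 3 (beyond the scatter). Compound 4 `O=C(O)[C@@H]1NC[C@H](O)[C@H](O)[C@H]1O` is the next stereoisomer in the series: the two compounds have the same atoms and bonds and differ only in configuration as drawn: 3 of 4 stereo elements differ; a stereocentre at a saturated ring carbon is drawn R in compound 3 and S in compound 4; a stereocentre at a saturated ring carbon is drawn R in compound 3 and S in compound 4; a stereocentre at a saturated ring carbon is drawn R in compound 3 and S in compound 4.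

Three measured steps involve only changes of configuration, and they bear on this one. The step of a number 3 percentage points higher from compound 1 to compound 3 (within the scatter) also inverted three of four stereocentres and stayed within the scatter. The step of a number 16.8 percentage points higher from compound 1 to compound 2 (beyond the scatter), a single inversion, was modest, and the mirror-image step a number 13.8 percentage points lower from compound 2 to compound 3 (beyond the scatter) was modest in the opposite direction. So configuration alone has moved this assay by modest amounts at most, and compound 4 is expected to sit near its neighbours, with a step of a number 3.8 percentage points higher from compound 3 to compound 4 (within the scatter) expected to be small. Compound 4 is estimated at 11% in this assay, within a range from 2% to 26%.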

Compound 4, a percentage reported as inhibition, at one concentration (the size of the read-out at that concentration, not a potency): 4.4%
Compound 4: middle estimate off by 6.6 percentage points, on the high side, within the range that was stated.
By their numbers in this assay, from the lowest: compounds 1, 4 and 3 (each within the scatter of the next); then compound 2.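

In this assay, inverting three stereocentres again stays within the scatter (a number 2.8 percentage points lower from compound 3 to compound 4 (within the scatter)), and inverting two does as well (a number 0.2 percentage points higher from compound 1 to compound 4 (within the scatter)). A single inversion starting from compound 2, however, goes beyond it (a number 16.6 percentage points lower from compound 2 to compound 4 (beyond the scatter)), so compound 2 now stands alone as the highest of the four, while compounds 1, 3 and 4 cannot be told apart. The size of a step does not follow the number of inverted stereocentres, since the full inversion between compound 2 and its mirror image, compound 3, also goes beyond the scatter (a number 13.8 percentage points lower from compound 2 to compound 3 (beyond the scatter)).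

The compounds shown leave open whether any stereoisomer outside this set would match or exceed compound 2. They also leave open whether a primary amide or a hydroxymethyl group in place of the carboxylic acid would change the number.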